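Butylsulfanyl in Place of Methoxypropoxy on the Shared Core

A few compounds are considered here, and "the series" means these few. Any claim that something is new, unique, unknown or untested is made for them only; others in the source may bear on it.

Measured so far:
compound 1, `CC(C)CCOc1nc(C(C)(C)C)ccc1CNC(=O)C(C)c1ccc(NS(C)(=O)=O)c(F)c1`, 0.8 nM
compound 2, `COCCCOc1nc(C(C)(C)C)ccc1CNC(=O)C(C)c1ccc(NS(C)(=O)=O)c(F)c1`, 5.6 nM

Both compounds were tested in an assay on cells for antagonist activity at transient receptor potential cation channel subfamily V member 1 (Homo sapiens), read by FLIPR and calcium flux, with a stated time of 6 min; on this read-out higher numbers stand for weaker inhibition and lower numbers for stronger inhibition. Among the measured compounds shown here, compound 2 holds the higher of the two numbers; the only neighbour is compound 1, and the single measured step, a 7.0-fold higher number from compound 1 to compound 2 (0.85 log units; beyond the scatter), came from trading the chain tail: methoxymethyl in place of isopropyl on a saturated chain carbon, two bonds along the chain from an oxygen on an aromatic ring.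

Compound 3, `CCCCSc1nc(C(C)(C)C)ccc1CNC(=O)C(C)c1ccc(NS(C)(=O)=O)c(F)c1`, is not yet measured. It differs from compound 2 in one place: butylsulfanyl in place of 3-methoxypropoxy on an aromatic carbon. This change touches the same side chain as the measured step, but it also swaps the atom that links the chain to the ring, so that step bears on it only in part. The entering chain carries no ether oxygen, which brings compound 3 nearer to compound 1 in that respect. For the measured compounds named here, the expectation is therefore a lower number than compound 2, with a 2.8-fold lower number from compound 2 to compound 3 (0.45 log units; beyond the scatter) as the estimated step, though a sulfur link has no precedent here and the range is wide. Compound 3 is estimated at 2 nM, between 0.5 nM and 10 nM.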

Compound 3, inhibition constant: 3.2 nM
Estimate against measurement, compound 3: 1.6-fold (0.20 log units) below, and the stated range covers the measured number.
By their numbers in this assay, from the lowest: compound 1; then compounds 3 and 2 (each within the scatter of the next).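

In this assay, butylsulfanyl in place of 3-methoxypropoxy gives a 1.8-fold lower number from compound 2 to compound 3 (0.24 log units; within the scatter) and so, on this aromatic carbon next to the ring nitrogen, the two chains cannot be told apart, even though they differ in their atom count and in their hydrogen-bond acceptors. Butylsulfanyl in place of isopentyloxy gives a 4.0-fold higher number from compound 1 to compound 3 (0.60 log units; beyond the scatter) and so compound 3, whose chain has no ether oxygen along its length, still stands apart from compound 1, which means that losing this oxygen does not by itself match compound 1, and the link atom and the tail of the chain both differ in this pair, so the step cannot be divided between them. Nothing shown here gives a measured reason for either step.

As far as these compounds go, a plain butoxy chain, with oxygen as the link and an unbranched tail, would separate those two differences, and how it would compare remains open. Also open, from the compounds shown here alone, is how a longer chain, or a chain ending in an amine, would read on this same aromatic carbon.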